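The compounds below may be only part of what the source reports. "The series", "measured", "known", "first", "only" and "open" are said of these compounds alone.

The measured compounds:
Compound 1, `Cc1noc(-c2cc3ccccc3[nH]2)n1`, in a functional assay on Jurkat cells (Homo sapiens) for antiproliferative activity, read by WST assay, with a stated time of 72 h (a higher number here means a weaker inhibitor, a lower number a stronger inhibitor), gives > 50000 nM, which is a limit of the assay and not a number.
Compound 2, `Cc1noc(-c2cc3cc(Cl)ccc3[nH]2)n1`, gives 21600 nM.

Compound 1 therefore stands only at a limit, (the limit of > 50000 nM in this assay, at which 1 of the 2 values shown sits), and no number is known for it. Among the compounds with values here, the single measured step, an at least 2.3-fold lower number from compound 1 to compound 2 (0.36 log units; beyond the scatter), concerns a change on a different aromatic carbon of the shared core than the one that carries the methyl group.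

Compound 3, `Nc1noc(-c2cc3ccccc3[nH]2)n1`, is the compound still to be measured. Its change from compound 1 is amino in place of methyl on an aromatic carbon. Within the data shown here, no measured step touches this position, so the expectation rests only on where compound 1 stands, which is at a limit. Compound 3 is expected to remain weak, and the expected step of a number no higher from compound 1 to compound 3 (the limit leaves the size open) is meant as none beyond the scatter. The estimate for compound 3 is 50000 nM, within 15000 nM to 150000 nM, with a fair chance that the assay again reports only a limit.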

Compound 3, half-maximal inhibitory concentration: > 50000 nM
Compound 3 was reported as a limit (the forecaster's own chance of this, stated with the estimate: 60%); the middle value lies on the limit itself.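

In this assay compound 3 gives > 50000 nM, which is a limit of the assay and not a number. Compound 1 also stands at a limit, so the step between compound 1 and compound 3 cannot be read: the limit of > 50000 nM in this assay, at which 2 of the 3 values shown sit.

The compounds shown leave open whether amino in place of methyl changes the number at all.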